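This account rests on a few compounds, and the source may have more. Where it says the series, first, only, none or still open, it means among the compounds named here.

Measured so far:
compound 1 `COc1cc2c(cc1N1CCN(C)CC1)N(C(=O)c1ccc(-c3cccc(C)n3)c3ccccc13)CC2`: 0.9
compound 2 `COc1cc2c(cc1N1C[C@@H](C)N(C)[C@@H](C)C1)N(C(=O)Nc1cccc(Cl)c1Cl)CC2`: 0.1

In an assay on isolated protein with 5-hydroxytryptamine receptor 1D (Homo sapiens) as the target (on this read-out higher numbers stand for larger maximal responses and lower numbers for smaller maximal responses), compound 1 gives 0.9, while compound 2 gives 0.1, so compound 2 stands lowest of the two numbers, with compound 1 a step higher that lies beyond the usual scatter. Within the data shown here, no single-change step between measured compounds is available here, and the two compounds differ in more than one place, so only their two values can be compared.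

Compound 3 `COc1cc2c(cc1N1CCN(C)CC1)N(C(=O)Nc1cccc(Cl)c1Cl)CC2` has not yet been measured. It differs from compound 2 in one place: 4-methylpiperazin-1-yl in place of 3,4,5-trimethylpiperazin-1-yl on an aromatic carbon. The group that enters is the same one that compound 1 carries on its core, and compound 1 shows the higher number in this assay. On that basis compound 3 is expected to rise from compound 2 by a moderate step, a number 0.25 higher from compound 2 to compound 3 (beyond the scatter), likely beyond the scatter. The estimate for compound 3 in this assay is 0.35, with a range from 0.1 to 0.7.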

Compound 3, intrinsic activity: the largest response reached, as a fraction of the reference agonist's: 0.7
For compound 3 the middle estimate is 0.35 below the measured one; low and high end bracket the measured number.
By their numbers in this assay, from the lowest: compound 2; then compound 3; then compound 1.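

Exchanging 3,4,5-trimethylpiperazin-1-yl for 4-methylpiperazin-1-yl on the aromatic carbon ortho to a methoxy group gives a number 0.60 higher from compound 2 to compound 3 (beyond the scatter) in this assay and shows that this single change can shift the maximal response by a large amount while the rest of the molecule stays the same. Compound 1 and compound 2 differ in more than one place, so their gap could not show what this position contributes. Nothing available bears on why the step is this large.

The compounds shown leave open whether a single added ring methyl would give the same drop as the 3,4,5-trimethylpiperazin-1-yl group with its defined stereocentres. They also leave open how a morpholine or an unsubstituted piperazine would read at this position.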